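Compound 2 to compound 4: a change on the chain

The compounds below may be only part of what the source reports. "The series", "measured", "known", "first", "only" and "open" are said of these compounds alone.

Values measured in an ADME assay on HEK293 cells (Homo sapiens) for cytotoxicity, read by resazurin assay, with a stated time of 16 h (a lower number here means that less compound is needed, a higher number that more compound is needed for the effect), are as follows
- Compound 1 `CCCOc1ccc(/C=C/C(=O)CC(=O)/C=C/c2ccc(OCCC)c(OC)c2)cc1OC` gives > 500000 nM as a limit of the assay
- Compound 2 `C=CCOc1ccc(/C=C/C(=O)CC(=O)/C=C/c2ccc(O)c(OC)c2)cc1OC` gives 270000 nM as a number
- Compound 3 `C=CCOc1ccc(/C=C/C(=O)CC(=O)/C=C/c2ccc(OCC=C)c(OC)c2)cc1OC` gives > 500000 nM as a limit of the assay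

Compound 2 is the only one in this set with a true number (270000 nM) to stand on. The rest of the set is described by the limit of > 500000 nM in this assay, at which 2 of the 3 values shown sit, and offers no number to rank against.

Compound 4 `COc1cc(/C=C/C(=O)CC(=O)/C=C/c2ccc(OCCO)c(OC)c2)ccc1O` has not yet been measured. It differs from compound 2 by hydroxymethyl in place of vinyl on a saturated chain carbon bound to an oxygen on an aromatic ring and this reads as hydroxymethyl in place of vinyl on a saturated chain carbon bound to an oxygen on an aromatic ring, or allyl to 2-hydroxyethyl.

Going by the values given here, only one measured step bears on this, and only loosely: an at least 1.8-fold higher number from compound 2 to compound 3 (0.26 log units; that floor lies within the scatter) comes from allyl in place of hydrogen on an oxygen on an aromatic ring, which is a different swap, and it ends on a limit. The expected result in this assay is a 1.1-fold lower number from compound 2 to compound 4 (0.03 log units; within the scatter) with no shift beyond the scatter expected in either direction. This expectation rests on compound 2 at 270000 nM as the sole anchor. For compound 4 the estimated value is 250000 nM with an expected range from 100000 nM to 500000 nM overall.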

Compound 4, half-maximal effective concentration: 25000 nM
Beside the measured number, compound 4's estimate is 10-fold (1.00 log units) above it, outside the stated range (below it).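

In this assay, hydroxymethyl in place of vinyl on a saturated chain carbon bound to an oxygen on an aromatic ring gives an 11-fold lower number from compound 2 to compound 4 (1.03 log units; beyond the scatter). Going by these compounds alone, this is the first step that clearly moves the number, whereas the only earlier step, an at least 1.8-fold higher number from compound 2 to compound 3 (0.26 log units; that floor lies within the scatter), is a different swap, ends on a limit and has a floor within the scatter. The position therefore responds in this assay to a change at the end of the chain alone, although the other compounds offer no number to rank against: the limit of > 500000 nM in this assay, at which 2 of the 4 values shown sit.

Compound 2 and compound 4 alone cannot separate the loss of the vinyl double bond from the arrival of the hydroxyl, and a plain propyl group at this place, with the rest of compound 2 unchanged, would pull the two apart. Also open, from the compounds shown here alone, is whether the lower number holds for a 2-aminoethyl group, a carboxylic acid or a longer chain ending in hydroxyl, and whether the same swap acts alike on the other side of the shared core.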